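Swapping the chain-end ring on a weak imide

The source may report more compounds than this note shows. Statements on the series, on what has been measured and on what is new or still open speak of the compounds shown alone.

Compound 1 `Cn1cc(C2=C(c3nn(CCCn4ccnc4)c4ncccc34)C(=O)N(c3ccccc3)C2=O)c2ccccc21` gives 6800 nM.
Compound 3 `Cn1cc(C2=C(c3nn(CCCCn4ccnc4)c4ncccc34)C(=O)N(c3ccccc3)C2=O)c2ccccc21` gives 47300 nM.
Compound 2 `Cn1cc(C2=C(c3nn(CCCCn4ccnc4)c4ncccc34)C(=O)NC2=O)c2ccccc21` gives > 100000 nM.

Of the three compounds tested in a functional assay on KB cells (Homo sapiens) for antiproliferative activity, read by MTT assay, with a stated time of 48 h (on this read-out lower numbers stand for stronger inhibition and higher numbers for weaker inhibition), compound 2 stands apart: its result is not a number but a limit of the assay, as the limit of > 100000 nM in this assay, at which 1 of the 3 values shown sits, records. Among the compounds with values here, the only steps measured so far run elsewhere. Lengthening the chain by one carbon, from compound 1 to compound 3, gave a 7.0-fold higher number from compound 1 to compound 3 (0.84 log units; beyond the scatter), and placing a phenyl on the ring nitrogen gave an at least 2.1-fold lower number from compound 2 to compound 3 (0.32 log units; beyond the scatter). Compound 4 `Cn1cc(C2=C(c3nn(CCCN4CCCCC4)c4ncccc34)C(=O)NC2=O)c2ccccc21` differs from compound 2 by piperidin-1-yl in place of (1H-imidazol-1-yl)methyl on a saturated chain carbon, three bonds along the chain from an aromatic nitrogen. Within the data shown here, neither measured step tests an imidazole ring against a piperidine ring, so no direct precedent exists; the chain-length step from compound 1 to compound 3 is the nearest relative but is not the same change. Compound 4 is therefore expected to sit near compound 2, with a step of an at least 1.6-fold lower number from compound 2 to compound 4 (0.22 log units; that floor lies within the scatter) being the most that seems plausible, and an estimated value of 60000 nM (range 15000 nM to 250000 nM).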

Compound 4, half-maximal inhibitory concentration: 98000 nM
Compound 4: the middle estimate sits 1.6-fold (0.21 log units) below what was measured; the range from low to high includes it.
By their numbers in this assay, from the lowest: compound 1; then compound 3; then compound 4. At a limit, above all of these: compound 2.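

Within the data shown here, this step is the first to change the chain-end ring itself, where the earlier steps changed only the chain length or the phenyl on the ring nitrogen. It gives an at least 1.0-fold lower number from compound 2 to compound 4 (0.00 log units; that floor lies within the scatter), so in this assay the exchange of 4-(1H-imidazol-1-yl)butyl for 3-(piperidin-1-yl)propyl, with the amide hydrogen kept, shows no gain that can be told from the scatter. The result for compound 2 remains a limit of the assay: the limit of > 100000 nM in this assay, at which 1 of the 4 values shown sits.

As far as these compounds go, it remains open whether 3-(piperidin-1-yl)propyl would behave differently on the phenyl-bearing imide of compound 1, whose chain ends in imidazole. Also open, from the compounds shown here alone, is whether a morpholine ring, a dimethylamino group or a longer chain ending in piperidine would move the number on either imide.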